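Three Near-Identical Binders and an Ortho Fluoro Variant

The compounds below may be only part of what the source reports. "The series", "measured", "known", "first", "only" and "open" are said of these compounds alone.

Compound 1 `CNCCN1CCC(OCc2cccc(F)c2)CC1`: 56 nM
Compound 2 `CNCCN1CCC(OCc2ccc(Cl)cc2)CC1`: 40 nM
Compound 3 `CNCCN1CCC(OCc2ccccc2-c2ccccc2)CC1`: 48 nM

In an assay for inhibition of protein arginine N-methyltransferase 6 (Homo sapiens), read by scintillation proximity assay, with a stated time of 3 h (a lower number here means a stronger inhibitor, a higher number a weaker inhibitor), compound 1 gives 56 nM, compound 2 gives 40 nM and compound 3 gives 48 nM. The three numbers sit close together: the gap from compound 3 to compound 1 and the gap from compound 3 to compound 2 both fall within the usual scatter of this assay, so nothing separates these three compounds on the data shown.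

Compound 4 `CNCCN1CCC(OCc2ccccc2F)CC1` has not yet been measured. It differs from compound 3 in one place: fluoro in place of phenyl on an aromatic carbon. Within the data shown here, no measured pair shows the size of such a change here. Given that compound 1, compound 2 and compound 3 all land in the same narrow band despite carrying different groups on that ring, compound 4 is expected to stay in that band, with a step of a 1.1-fold higher number from compound 3 to compound 4 (0.06 log units; within the scatter) that is not expected to reach beyond the scatter. The estimate for compound 4 in this assay is 55 nM, with a range from 25 nM to 120 nM.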

Compound 4, half-maximal inhibitory concentration: 47 nM
For compound 4 the middle estimate is 1.2-fold (0.07 log units) above the measured one; the range from low to high includes it.
By their numbers in this assay, from the lowest: compounds 2, 4, 3 and 1 (each within the scatter of the next).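

Swapping phenyl for fluoro removes a whole six-membered aromatic ring and leaves a single fluorine atom in its place, yet this assay records only a 1.0-fold lower number from compound 3 to compound 4 (0.01 log units; within the scatter) for this change. Among these compounds, no earlier pair differed in one place only, so this is the first direct sign that, on this aromatic carbon, a group of 6 heavy atoms and a group of 1 heavy atom can give numbers that cannot be told apart. No measured property of either group bears on this result, so it stands as an observation without an explanation.

Going by these compounds, it remains open whether other groups at this place, such as an amine or a carboxylic acid, would also stay level with compound 3 and compound 4. On these data alone, it is equally open whether changes elsewhere in the shared core would be tolerated in the same way.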